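Swapping the Pyridine for a Methoxyphenyl on the Side Chain

This account rests on a few compounds, and the source may have more. Where it says the series, first, only, none or still open, it means among the compounds named here.

Of the compounds shown here, three that share one core have been measured in an assay on isolated protein for inhibition of aldehyde dehydrogenase 1A1 (Homo sapiens); a higher number here means a weaker inhibitor, a lower number a stronger inhibitor. Compound 1 `COc1cccc(C(C)Sc2nc3c(cnn3C)c(=O)n2-c2ccccc2)c1` gives 451 nM. Compound 2 `CC(Sc1nc2c(cnn2C)c(=O)n1-c1ccccc1)c1cccc(F)c1` gives 151 nM, and compound 3 `CC(Sc1nc2c(cnn2C)c(=O)n1-c1ccccc1)c1cccnc1` gives 139 nM. For the measured compounds named here, compound 3 thus has the lowest number of the three, but its gap to compound 2 lies within the scatter, so the two cannot be ranked; only the step of a 3.2-fold lower number from compound 1 to compound 3 (0.51 log units; beyond the scatter) is clearly larger than the scatter.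

The next compound, compound 4 `COc1ccccc1C(C)Sc1nc2c(cnn2C)c(=O)n1-c1ccccc1`, differs from compound 3 in one place: 2-methoxyphenyl in place of pyridin-3-yl on a saturated chain carbon bound to a saturated chain carbon and a sulfur. Going by the values given here, no measured pair shows this exact exchange. The nearest guide is the step of a 3.2-fold lower number from compound 1 to compound 3 (0.51 log units; beyond the scatter), in which a 3-methoxyphenyl gave way to the same pyridin-3-yl; compound 4 runs that exchange backwards, though with a 2-methoxyphenyl rather than a 3-methoxyphenyl. The step of a 3.0-fold lower number from compound 1 to compound 2 (0.48 log units; beyond the scatter) shows that changing this ring shifts the number by a modest amount. A return toward a methoxyphenyl is therefore expected to raise the number modestly, with real uncertainty because the methoxy group now sits in a different spot.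

Compound 4 is expected to give about 300 nM, with a range from 120 nM to 800 nM. This expectation corresponds to a step of a 2.2-fold higher number from compound 3 to compound 4 (0.33 log units; beyond the scatter).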

Compound 4, half-maximal inhibitory concentration: 445 nM
Beside the measured number, compound 4's estimate is 1.5-fold (0.17 log units) below it; the range from low to high includes it.
By their numbers in this assay, from the lowest: compounds 3 and 2 (each within the scatter of the next); then compounds 4 and 1 (each within the scatter of the next).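

In this assay, putting a 2-methoxyphenyl on this saturated chain carbon gives a similar loss whether it replaces the pyridin-3-yl (a 3.2-fold higher number from compound 3 to compound 4 (0.51 log units; beyond the scatter)) or the 3-fluorophenyl (a 2.9-fold higher number from compound 2 to compound 4 (0.47 log units; beyond the scatter)). What is new is that the two methoxyphenyl rings cannot be told apart (a 1.0-fold lower number from compound 1 to compound 4 (0.01 log units; within the scatter)), so moving the methoxy group from the 3-position of the ring to the 2-position makes no readable difference, and the four compounds fall into two groups: the methoxyphenyl pair, with the higher numbers, and the 3-fluorophenyl and pyridin-3-yl pair, with the lower numbers. Nothing measured here explains why the compounds split this way.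

As far as these compounds go, it remains open whether a plain phenyl with no added group would sit with the lower pair or the higher pair, and whether a 4-methoxyphenyl would match the two methoxyphenyl rings already seen. A 2-fluorophenyl would show whether the 3-fluorophenyl result carries over to the other ring position, while an ethoxy or a hydroxyl group would test how much of the methoxy group this position accepts.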